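This account rests on a few compounds, and the source may have more. Where it says the series, first, only, none or still open, it means among the compounds named here.

Measured in a functional assay on HCT-15 cells (Homo sapiens); on this read-out higher numbers stand for an effect only at larger amounts of compound and lower numbers for an effect already at smaller amounts:
- compound 1 `COc1cc(C2OC(c3ccc(N(C)C)cc3)=NN2C(C)=O)cc(OC)c1OC` gives 0.033 uM
- compound 2 `COc1cc(C2OC(c3ccccc3N(C)C)=NN2C(C)=O)cc(OC)c1OC` gives 65 uM
- compound 3 `COc1ccc(C2OC(c3ccc(N(C)C)cc3)=NN2C(C)=O)c(OC)c1OC` gives 7.5 uM

Compound 3 stands second highest of the three numbers, above compound 1 and below compound 2. Compound 4 `COc1ccc(C2OC(c3ccc(N(C)C)cc3)=NN2C(C)=O)cc1OC` carries hydrogen in place of methoxy on an aromatic carbon of compound 3 : hydrogen in place of methoxy on an aromatic carbon. Among the compounds with values here, the one measured step, a 2000-fold higher number from compound 1 to compound 2 (3.29 log units; beyond the scatter), involves no methoxy group and shows only that a single change can move numbers far in this assay. Within the data shown here, no measured step removes a methoxy group, so the direction stays uncertain. Compound 1 at 0.033 uM leaves room towards lower numbers. An estimated step of a 2.5-fold lower number from compound 3 to compound 4 (0.40 log units; beyond the scatter) is expected, with wide uncertainty. For compound 4 the expected value is 3 uM, estimated between 0.3 uM and 20 uM.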

Compound 4, concentration for half-maximal effect: 8.2 uM
Estimate against measurement, compound 4: 2.7-fold (0.44 log units) below, and the stated range covers the measured number.
By their numbers in this assay, from the lowest: compound 1; then compounds 3 and 4 (each within the scatter of the next); then compound 2.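

At the carbon ortho to a large group, hydrogen in place of methoxy costs nothing measurable, with a 1.1-fold higher number from compound 3 to compound 4 (0.04 log units; within the scatter). The same replacement at another carbon of the ring gives a 250-fold higher number from compound 1 to compound 4 (2.40 log units; beyond the scatter), so this change does not act alike at every place on the ring, and what matters here is where the methoxy group sits, not only how many are present. Nothing measured here speaks to the cause of this contrast.

Open, going by these compounds, is whether fluorine or an amine at the first carbon would stay as flat as hydrogen does. Also open, on these data alone, is whether the large step from compound 1 would hold with the 2-(dimethylamino)phenyl of compound 2.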